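Pyrazin-2-yl for pyridazin-3-yl: notes on compound 4

The source may hold more compounds than are shown below. What is called first, only, known or untested is meant among the compounds shown, and "the series" means these compounds.

Measured so far in a physicochemical assay for solubility, in phosphate buffer, with a stated time of 2 h, at pH 7.4 (on this read-out lower numbers stand for lower solubility and higher numbers for higher solubility), for this series
- Compound 1 `COc1ccc(Nc2nc(-c3ccccn3)cs2)cc1` gives 80000 nM
- Compound 2 `Clc1ccc(Nc2nc(-c3cccnn3)cs2)nc1` gives 20000 nM
- Compound 3 `Clc1ccc(Nc2nc(-c3cccnn3)c(Cl)s2)nc1` gives < 10000 nM as a limit of the assay, not a number

Of the two actual numbers, compound 2 is the lower at 20000 nM and compound 1 stands higher at 80000 nM with the gap beyond the scatter.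

Compound 4 `Clc1ccc(Nc2nc(-c3cnccn3)cs2)nc1` carries pyrazin-2-yl in place of pyridazin-3-yl on an aromatic carbon and is still unmeasured.

Among the measured compounds shown here, the only measured step runs an at least 2.0-fold lower number from compound 2 to compound 3 (0.30 log units; that floor lies within the scatter) and ends on a limit (the limit of < 10000 nM in this assay, at which 1 of the 3 values shown sits) with chloro in place of hydrogen on an aromatic carbon. That is a different change and gives no size for this one. The expected outcome is a 1.3-fold lower number from compound 2 to compound 4 (0.12 log units; within the scatter) and no step beyond the scatter is expected.

For compound 4 the estimate is 15000 nM with an expected range of 10000 nM to 40000 nM in this assay as a working figure.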

Compound 4, solubility: < 10000 nM
Compound 4 was reported as a limit; the forecaster's own chance of this, stated with the estimate: 30%; middle value at least 1.5-fold (0.17 log units) from the limit.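

In this assay, pyrazin-2-yl in place of pyridazin-3-yl, with the same atoms joined differently, gives an at least 2.0-fold lower number from compound 2 to compound 4 (0.30 log units; that floor lies within the scatter), so this position has its first measured ring exchange, though that floor alone does not establish a real change. Compound 4 gives < 10000 nM, which is a limit of the assay and not a number. The series now reaches this limit through a second, different change: the limit of < 10000 nM in this assay, at which 2 of the 4 values shown sit.

Going by these compounds, the true size of the step remains open, as does the value of compound 4 beyond the limit. Also open, on these data alone, is how an amine or a carboxylic acid on the pyrazin-2-yl ring would read in this assay.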